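Series notes: a 2-bromophenyl variant of the shared core

The compounds below may be only part of what the source reports. "The series", "measured", "known", "first", "only" and "open" are said of these compounds alone.

Measured so far:
compound 1, `CCCn1c(=O)[nH]c2nc(-c3ccc(S(=O)(=O)N4CCN(c5ccc(Br)cc5)CC4)cc3)[nH]c2c1=O`: 13% in an assay on CHO cells for displacement of a labelled ligand from adenosine receptor A1 (Homo sapiens), read by scintillation counting, with a stated time of 90 min, tested at 1 uM, in the presence of a further agent that is not named here; a lower number here means less inhibition, a higher number more inhibition at the concentration tested (going by the name of the read-out)
compound 2, `CCCn1c(=O)[nH]c2nc(-c3ccc(S(=O)(=O)N4CCN(c5cccc(Cl)c5)CC4)cc3)[nH]c2c1=O`: 21% in this assay

Of the two numbers shown, compound 2 carries the higher one, but a number 8 percentage points higher from compound 1 to compound 2 (within the scatter) lies within the scatter, so no order between compound 1 and compound 2 can be read from these data. Both sit at low inhibition at the concentration tested.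

Compound 3, `CCCn1c(=O)[nH]c2nc(-c3ccc(S(=O)(=O)N4CCN(c5ccccc5Br)CC4)cc3)[nH]c2c1=O`, is not yet measured. It differs from compound 2 in one place: 2-bromophenyl in place of 3-chlorophenyl on an amine nitrogen in a ring. Among the measured compounds shown here, the only measured step that bears on this change is the one from compound 1 to compound 2, which likewise exchanges one halogen-bearing phenyl for another on the same amine nitrogen in a ring, and that step was a number 8 percentage points higher from compound 1 to compound 2 (within the scatter), within the scatter. On that basis no step beyond the scatter is expected in this assay for compound 3, in either direction, and the expected step is a number 4 percentage points lower from compound 2 to compound 3 (within the scatter). Compound 3 is therefore estimated at 17%, with a range from 5% to 30%, pending measurement.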

Compound 3, a percentage reported as inhibition, at one concentration (the size of the read-out at that concentration, not a potency): 28%
Estimate against measurement, compound 3: 11 percentage points below; the measured number falls inside the stated range.
By their numbers in this assay, from the lowest: compounds 1, 2 and 3 (each within the scatter of the next, the first and the last beyond it).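

In this assay, among the compounds shown here, 2-bromophenyl in place of 4-bromophenyl on an amine nitrogen in a ring gives a number 15 percentage points higher from compound 1 to compound 3 (beyond the scatter), the first step at this position to clear the scatter, so the choice between these two bromophenyl groups does register in this read-out, though only modestly. For the compounds shown here, the exchange of 3-chlorophenyl for 2-bromophenyl at the same place gives a number 7 percentage points higher from compound 2 to compound 3 (within the scatter), so compound 2 and compound 3 cannot be ordered, and the series so far separates only its two bromophenyl members from each other. The data shown offer no measurement that would account for the step between those two members.

Going by these compounds alone, compound 1 and compound 3 are the only pair here that keeps the same halogen, so it remains open whether a 2-chlorophenyl would track compound 3 or whether the 3-bromophenyl would fall with compound 1 or compound 3. Also open, going by these compounds, is how a phenyl with no halogen, or a 2-methoxyphenyl or 2-methylphenyl, on the same amine nitrogen would read in this assay, and whether any group at this place can lift inhibition well beyond the modest step seen here.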